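From tert-butyl to methyl on compound 1

This account rests on a few compounds, and the source may have more. Where it says the series, first, only, none or still open, it means among the compounds named here.

In an ADME assay (liver) for metabolic stability, with Liver microsome (Rattus norvegicus) as the target, read by LC-MS, using microsomes and NADPH, with stated times of 5 min and 60 min, tested at 4 uM (on this read-out higher numbers stand for a more stable compound and lower numbers for a less stable compound), compound 1 `Cc1c(OCCCCOc2ccc(F)c(C(=O)O)c2)ccc(C(=O)CC(C)(C)C)c1O` gives 58% and compound 2 `Cc1c(OCCCCOc2ccc(C(=O)CC(C)(C)C)c(O)c2C)cccc1C(=O)O` gives 51%, so compound 1 has one close neighbour. Among the measured compounds shown here, the only measured step is a number 7 percentage points lower from compound 1 to compound 2 (within the scatter), and it lies at a different place in the structure. Compound 3 `CCC(=O)c1ccc(OCCCCOc2ccc(F)c(C(=O)O)c2)c(C)c1O` carries methyl in place of tert-butyl on a saturated chain carbon bound to a carbonyl carbon, with methyl in place of tert-butyl on a saturated chain carbon bound to a carbonyl carbon. For the measured compounds named here, no measured step covers this change, so the range stays wide and no step beyond the scatter is expected. The expected step is a number 2 percentage points higher from compound 1 to compound 3 (within the scatter). For compound 3 the estimated value is 60%, with an expected range of 40% to 78%.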

Compound 3, percent of the compound remaining: 35%
Beside the measured number, compound 3's estimate is 25 percentage points above it; measured number below the stated range.
By their numbers in this assay, from the lowest: compound 3; then compounds 2 and 1 (each within the scatter of the next).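

Among the compounds shown here, on a saturated chain carbon bound to a carbonyl carbon, methyl in place of tert-butyl gives a number 23 percentage points lower from compound 1 to compound 3 (beyond the scatter) in this assay, so this position matters for the read-out, whereas the one earlier measured step stayed within the scatter. This is a single pair, and the data offer no measured explanation for the step.

The compounds shown leave open whether an isopropyl group or a longer chain at this place would read closer to compound 1 or to compound 3. Also open, on these data alone, is whether the same change on compound 2 gives a step of similar size.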